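Amine terminus swap in the quinoline ether anilide series

The compounds below may be only part of what the source reports. "The series", "measured", "known", "first", "only" and "open" are said of these compounds alone.

Measured so far in a functional assay on A549 cells (Homo sapiens) for cytotoxicity, read by MTT assay, with a stated time of 72 h; on this read-out lower numbers stand for stronger inhibition and higher numbers for weaker inhibition:
- compound 1 `COc1cc2c(Oc3ccc(NC(=O)c4cn(-c5ccccc5C)nn4)cc3F)ccnc2cc1OCCCN1CCCC1` gives 900 nM
- compound 2 `COc1cc2c(Oc3ccc(NC(=O)c4cn(-c5ccccc5)nn4)cc3F)ccnc2cc1OCCCN1CCC(C)CC1` gives 140 nM
- compound 3 `COc1cc2c(Oc3ccc(NC(=O)c4cn(-c5ccccc5C)nn4)cc3F)ccnc2cc1OCCCN1CCC(C)CC1` gives 3500 nM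

Compound 3 stands at the highest number of the three in this assay: compound 1 is the nearest, compound 2 the furthest, both steps beyond the scatter.

Compound 4 `COc1cc2c(Oc3ccc(NC(=O)c4cn(-c5ccccc5C)nn4)cc3F)ccnc2cc1OCCCN1CCN(C)CC1` is the next member and is unmeasured. It differs from compound 3 by 4-methylpiperazin-1-yl in place of 4-methylpiperidin-1-yl on a saturated chain carbon, three bonds along the chain from an oxygen on an aromatic ring.

Of the measured steps, only one touches the same place: a 3.9-fold higher number from compound 1 to compound 3 (0.59 log units; beyond the scatter), a modest shift on changing the amine at the end of the chain. The other step, a 25-fold higher number from compound 2 to compound 3 (1.40 log units; beyond the scatter), concerns the methyl on the aromatic ring and does not bear on this change; compound 4 keeps that methyl. Replacing the ring at the chain end has so far moved this assay by a modest amount only. The expectation for compound 4 in this assay is therefore a small step, if any, with the direction uncertain and a lower number somewhat more likely, given a 3.9-fold higher number from compound 1 to compound 3 (0.59 log units; beyond the scatter) ran upward on moving away from the smaller amine. The estimate for compound 4 is 2000 nM, within 600 nM to 6000 nM, meaning a 1.8-fold lower number from compound 3 to compound 4 (0.24 log units; within the scatter).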

Compound 4, half-maximal inhibitory concentration: 3100 nM
Beside the measured number, compound 4's estimate is 1.6-fold (0.19 log units) below it; the range from low to high includes it.
By their numbers in this assay, from the lowest: compound 2; then compound 1; then compounds 4 and 3 (each within the scatter of the next).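

In this assay, 4-methylpiperazin-1-yl in place of 4-methylpiperidin-1-yl gives a 1.1-fold lower number from compound 3 to compound 4 (0.05 log units; within the scatter), so this exchange in the six-membered ring at the end of the 3-carbon propyl chain has no readable effect in the presence of the aromatic methyl. Pyrrolidin-1-yl stays apart from both six-membered rings, with a 3.4-fold higher number from compound 1 to compound 4 (0.54 log units; beyond the scatter) matching in size the earlier 3.9-fold higher number from compound 1 to compound 3 (0.59 log units; beyond the scatter), and among compounds 1, 3 and 4 the read-out therefore separates the pyrrolidine compound from the other two, with no exception in this set of three. Nothing shown gives a reason for this pattern.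

On these data alone, it remains open whether the same exchange is as silent on the core of compound 2, which lacks the aromatic methyl. A morpholin-4-yl or dimethylamino group at the chain end, or a shorter ethyl linker, would test how far this flat response extends.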